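The source may hold more compounds than are shown below. What is called first, only, known or untested is meant among the compounds shown, and "the series" means these compounds.

Compound 1 `O=C1/C(=C\c2ccc(Cl)cc2)S/C(=N/c2ccccc2)N1Cc1ccncc1`: 28800 nM
Compound 2 `COc1cc(/C=C2/S/C(=N/c3ccccc3)N(Cc3ccncc3)C2=O)ccc1O`: 28600 nM
Compound 3 `CCOc1cc(/C=C2/S/C(=N/c3ccccc3)N(Cc3ccncc3)C2=O)ccc1O`: 20400 nM

All three values come from a functional assay on HepG2 cells (Homo sapiens) for cytotoxicity, read by MTT assay, with a stated time of 48 h; on this read-out lower numbers stand for stronger inhibition and higher numbers for weaker inhibition. Going by the values given here, compound 3, at 20400 nM, stands within the scatter of both other compounds, so the series so far shows no clear separation.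

The next compound is compound 4 `O=C1/C(=C\c2cccc(Cl)c2)S/C(=N/c2ccccc2)N1Cc1ccncc1`, in which 3-chlorophenyl takes the place of 3-ethoxy-4-hydroxyphenyl on a double-bonded chain carbon bound to a double-bonded ring carbon: 3-chlorophenyl in place of 3-ethoxy-4-hydroxyphenyl on a double-bonded chain carbon bound to a double-bonded ring carbon.

Among the compounds with values here, three measured steps bear on this change. The closest is a 1.4-fold lower number from compound 1 to compound 3 (0.15 log units; within the scatter), which exchanges 4-chlorophenyl for the same 3-ethoxy-4-hydroxyphenyl group and stays within the scatter. The other two, a 1.0-fold lower number from compound 1 to compound 2 (0.00 log units; within the scatter) and a 1.4-fold lower number from compound 2 to compound 3 (0.15 log units; within the scatter), are also within the scatter. Within the data shown here, no measured pair shows what 3-chlorophenyl does in place of 4-chlorophenyl, so that part of the change remains untested. Compound 1 still offers the best guide, as its chlorophenyl group gives 28800 nM.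

In this assay, no step beyond the scatter is therefore expected, and any small shift would be toward a higher number. The estimated step is a 1.3-fold higher number from compound 3 to compound 4 (0.12 log units; within the scatter). For compound 4 the expected value is 27000 nM, with an estimated range from 13000 nM to 55000 nM.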

Compound 4, half-maximal inhibitory concentration: 28900 nM
Compound 4: middle estimate off by 1.1-fold (0.03 log units), on the low side; low and high end bracket the measured number.
By their numbers in this assay, from the lowest: compounds 3, 2, 1 and 4 (each within the scatter of the next).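

In this assay, going by these compounds alone, the exchange of 4-chlorophenyl for 3-chlorophenyl on a double-bonded chain carbon bound to a double-bonded ring carbon gives a 1.0-fold higher number from compound 1 to compound 4 (0.00 log units; within the scatter) and so provides the first measured comparison of these two chlorophenyl groups at this place. The exchanges of the two oxygen-bearing groups for 3-chlorophenyl give a 1.0-fold higher number from compound 2 to compound 4 (0.00 log units; within the scatter) and a 1.4-fold higher number from compound 3 to compound 4 (0.15 log units; within the scatter) and thus extend the flat picture to a group with 0 hydrogen-bond donors and 0 hydrogen-bond acceptors, in place of groups that each carry a hydrogen-bond donor and hydrogen-bond acceptors. Nothing measured here accounts for this lack of separation among the four compounds.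

The compounds shown leave open whether any group at this place can move the number beyond the scatter, for example a phenyl carrying a dimethylamino group or a carboxylic acid, or one carrying a longer alkoxy chain than the ethoxy of 3-ethoxy-4-hydroxyphenyl. They also leave open whether a change elsewhere on the shared core would separate these compounds in this assay.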